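This account rests on a few compounds, and the source may have more. Where it says the series, first, only, none or still open, it means among the compounds named here.

Compound 1 `COc1ccc(C(=O)/C=C/c2cc(-c3cc(OC)c(OC)c(OC)c3)n[nH]2)cc1OC` was measured in a functional assay on MOLT-4 cells (Homo sapiens) for inhibition, read by sulforhodamine B assay, with a stated time of 48 h (a lower number here means a stronger inhibitor of growth, a higher number a weaker inhibitor of growth), where compound 1 gives 5560 nM. Going by the values given here, its only companion is compound 2 `COc1cc(-c2cc(/C=C/C(=O)c3ccc(F)c(F)c3)[nH]n2)cc(OC)c1OC`, which in this assay gives 9090 nM. The two differ on the carbonyl side, with a 3,4-difluorophenyl in place of a 3,4-dimethoxyphenyl, and the step of a 1.6-fold higher number from compound 1 to compound 2 (0.21 log units; within the scatter) stays within the scatter, so the two numbers cannot be told apart and neither compound can be called the stronger growth inhibitor.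

Compound 3 `COc1cc(C(=O)/C=C/c2cc(-c3cc(OC)c(OC)c(OC)c3)n[nH]2)cc(OC)c1OC` keeps the carbonyl-side ring of compound 1 and changes the other end of the molecule: methoxy in place of hydrogen on an aromatic carbon. Among the compounds with values here, no measured step touches that ring, so nothing shows directly what such an addition does. Within the data shown here, the single step that has been measured, from compound 1 to compound 2, concerns a different place and was within the scatter. With no evidence pointing either way, the step of a 1.1-fold higher number from compound 1 to compound 3 (0.03 log units; within the scatter) is expected to stay within the scatter, and compound 3 is estimated to give about 6000 nM in this assay, most likely between 2000 nM and 20000 nM.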

Compound 3, concentration for total growth inhibition: 8950 nM
Compound 3: middle estimate off by 1.5-fold (0.17 log units), on the low side; the measured number falls inside the stated range.
By their numbers in this assay, from the lowest: compounds 1, 3 and 2 (each within the scatter of the next).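

Adding a methoxy to the ring that carries the carbonyl, on an aromatic carbon ortho to a methoxy group and meta to a large group, gives a 1.6-fold higher number from compound 1 to compound 3 (0.21 log units; within the scatter) in this assay, so this added group produces no change that can be told from the scatter. Going by these compounds alone, this is the first direct look at filling this hydrogen position, and it shows that compound 3 cannot be separated from compound 1 even though it carries a methoxy there in place of a hydrogen atom. No separate measurement on these compounds bears on what lies behind this result, so the reading stops at the growth numbers.

Going by these compounds, a single methoxy is only one test of this position, so it remains open whether a different group there, such as an amine, a carboxylic acid or a longer chain like butoxy, would give a step beyond the scatter. On these data alone, it is also open whether removing either of the methoxy groups already on this ring would move the number.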